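Benzyloxy in place of isopentyloxy on the anilide acid

This account rests on a few compounds, and the source may have more. Where it says the series, first, only, none or still open, it means among the compounds named here.

Notes on the alkoxy series. Compound 1 `CCCCOc1cccc(C(=O)Nc2cccc(C(=O)O)c2)c1` gives 3150 nM in an assay on isolated protein for agonist activity at Bile acid receptor (Homo sapiens), read by TR-FRET, with a stated time of 3 h, in the absence of a further agent; on this read-out higher numbers stand for an effect only at larger amounts of compound and lower numbers for an effect already at smaller amounts. Compound 2 `CCCCCOc1cccc(C(=O)Nc2cccc(C(=O)O)c2)c1` gives 2540 nM in this assay, and compound 3 `CC(C)CCOc1cccc(C(=O)Nc2cccc(C(=O)O)c2)c1` gives 2760 nM in this assay. Compound 3 thus stands second highest of the three numbers; its nearest neighbour is compound 2 and its furthest compound 1, and both gaps sit within the scatter, so no order among the three can be read from these values.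

Compound 4 `O=C(O)c1cccc(NC(=O)c2cccc(OCc3ccccc3)c2)c1` differs from compound 3 by phenyl in place of isobutyl on a saturated chain carbon bound to an oxygen on an aromatic ring. The measured steps all rework the saturated chain at the same end of the shared core: a 1.2-fold lower number from compound 1 to compound 2 (0.09 log units; within the scatter), a 1.1-fold lower number from compound 1 to compound 3 (0.06 log units; within the scatter) and a 1.1-fold higher number from compound 2 to compound 3 (0.04 log units; within the scatter). Among the measured compounds shown here, none of them exchanges a chain for a ring, so no step speaks to the change itself; what they show is that rebuilding this chain has left this assay unmoved beyond the scatter. On that basis a step of a 1.4-fold lower number from compound 3 to compound 4 (0.14 log units; within the scatter) is expected, essentially no change. For the measured compounds named here, the range is set wide; no measured pair covers a swap to phenyl. Compound 4 is therefore estimated at 2000 nM in this assay, with a range of 600 nM to 6500 nM.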

Compound 4, half-maximal effective concentration: 1160 nM
Estimate against measurement, compound 4: 1.7-fold (0.24 log units) above, within the range that was stated.
By their numbers in this assay, from the lowest: compound 4; then compounds 2, 3 and 1 (each within the scatter of the next).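

In this assay, among the compounds shown here, phenyl in place of isobutyl on a saturated chain carbon bound to an oxygen on an aromatic ring is the first change to exceed the scatter (a 2.4-fold lower number from compound 3 to compound 4 (0.38 log units; beyond the scatter)), and the steps from the other two chains agree (a 2.2-fold lower number from compound 2 to compound 4 (0.34 log units; beyond the scatter); a 2.7-fold lower number from compound 1 to compound 4 (0.43 log units; beyond the scatter)). All three steps are modest, but they show that this position can respond to a change in the type of group, whereas butyl, pentyl and isopentyl chains on the oxygen remain within the scatter of one another, leaving compound 4 alone apart from the three. Nothing at hand explains why the phenyl group gives the lower number.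

The compounds shown leave open whether this step follows from the aromatic ring or from any ring, a question that a cyclohexyl group at the same place would address. Also open, from the compounds shown here alone, is whether the step grows, holds or reverses with a pyridyl ring, a chlorophenyl group or a longer chain carrying the phenyl, such as phenethyl.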